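Swapping 2-methylcyclohexyl for 4-methylcyclohexyl in the series

The compounds below may be only part of what the source reports. "The series", "measured", "known", "first", "only" and "open" are said of these compounds alone.

In an ADME assay on microsomes from liver (Mus musculus) for metabolic stability, read by LC-MS (on this read-out lower numbers stand for slow clearance and higher numbers for fast clearance), compound 3 `C[C@H]1CCCC[C@H]1NC(=O)c1cc2c(F)cc(F)cc2[nH]1` gives 660 mL.min-1.g-1. Compound 1 `Cc1cc(C)c2cc(C(=O)N[C@@H]3CCCC[C@@H]3C)[nH]c2c1` gives 433 mL.min-1.g-1, within the scatter of compound 3. Compound 2 `CC1CCC(NC(=O)c2cc3c(Cl)cc(Cl)cc3[nH]2)CC1` gives 37 mL.min-1.g-1, lower than compound 3 beyond the scatter. Compound 4 `CC1CCC(NC(=O)c2cc3c(F)cc(F)cc3[nH]2)CC1` keeps the core of compound 3 and has 4-methylcyclohexyl in place of 2-methylcyclohexyl on an amide-type nitrogen. Among the measured compounds shown here, no measured pair differs in this place alone. For the measured compounds named here, the only measured compound with 4-methylcyclohexyl is compound 2 at 37 mL.min-1.g-1, though its core differs, so only part of that gap is expected to carry over. The expected step of a 3.3-fold lower number from compound 3 to compound 4 (0.52 log units; beyond the scatter) in this assay is downward, beyond the scatter. Compound 4 is estimated at 200 mL.min-1.g-1, with an expected range of 70 mL.min-1.g-1 to 550 mL.min-1.g-1.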

Compound 4, intrinsic clearance in microsomes: 866 mL.min-1.g-1
Estimate against measurement, compound 4: 4.3-fold (0.64 log units) below; the whole stated range lies below it.
By their numbers in this assay, from the lowest: compound 2; then compounds 1, 3 and 4 (each within the scatter of the next).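

In this assay, 4-methylcyclohexyl in place of 2-methylcyclohexyl on an amide-type nitrogen gives a 1.3-fold higher number from compound 3 to compound 4 (0.12 log units; within the scatter), so this change does not separate the two compounds on this core. The low number of compound 2 at 37 mL.min-1.g-1 therefore does not follow from 4-methylcyclohexyl alone. Nothing at hand explains why the swap leaves the read-out within the scatter.

Open, on these data alone, is whether the chlorine atoms on the core of compound 2 carry its number. Also open, as far as these compounds go, is whether a hydroxyl or a carboxylic acid in place of the methyl on the cyclohexyl ring would shift clearance.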